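The source may hold more compounds than are shown below. What is called first, only, known or untested is meant among the compounds shown, and "the series" means these compounds.

Measured so far:
Compound 1, `O=C(COc1ccc2cc(/C=C3/SC(=O)NC3=O)ccc2c1)Nc1ccc(Br)cc1F`: in an assay on isolated protein for inhibition of histone deacetylase 8 (Homo sapiens), with a stated time of 1 h (a lower number here means a stronger inhibitor, a higher number a weaker inhibitor), compound 1 gives only a limit of the assay, > 50000 nM.
Compound 2, `O=C(COc1ccc2cc(/C=C3/SC(=O)NC3=O)ccc2c1)Nc1cccc(F)n1`: in this assay compound 2 gives 7200 nM.
Compound 3, `O=C(COc1ccc2cc(/C=C3/SC(=O)NC3=O)ccc2c1)Nc1ccccc1`: in this assay compound 3 gives 4500 nM.

Compound 1 stands at the weak end of the three; its value is a limit, so only a range is known for it (the limit of > 50000 nM in this assay, at which 1 of the 3 values shown sits). The steps away from it are sizeable, an at least 6.9-fold lower number from compound 1 to compound 2 (0.84 log units; beyond the scatter) and an at least 11-fold lower number from compound 1 to compound 3 (1.04 log units; beyond the scatter), while a 1.6-fold lower number from compound 2 to compound 3 (0.20 log units; within the scatter). Compound 4, `Cc1cc(Br)ccc1NC(=O)COc1ccc2cc(/C=C3/SC(=O)NC3=O)ccc2c1`, differs from compound 1 by methyl in place of fluoro on an aromatic carbon; the bromo group stays. Going by the values given here, no measured step exchanges fluoro for methyl with the bromo group kept, so the measured steps, which each replace the whole aryl group, bear only indirectly. Compound 4 is therefore expected to remain a weak inhibitor, with the step of an at least 1.2-fold lower number from compound 1 to compound 4 (0.09 log units; that floor lies within the scatter) expected to lie within the scatter and a fair chance of another limit. Compound 4 is estimated at 40000 nM, range 12000 nM to 150000 nM.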

Compound 4, half-maximal inhibitory concentration: 7400 nM
Compound 4: middle estimate off by 5.4-fold (0.73 log units), on the high side, outside the stated range (below it).
By their numbers in this assay, from the lowest: compounds 3, 2 and 4 (each within the scatter of the next). At a limit, above all of these: compound 1.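

In this assay, the bromo group alone does not account for the weakness of compound 1: with it kept, methyl in place of fluoro gives an at least 6.7-fold lower number from compound 1 to compound 4 (0.82 log units; beyond the scatter). The value of compound 1 is a limit, so this step is only a floor: the limit of > 50000 nM in this assay, at which 1 of the 4 values shown sits. Exchanging the whole aryl group for 4-bromo-2-methylphenyl shows nothing beyond the scatter, with a 1.6-fold higher number from compound 3 to compound 4 (0.22 log units; within the scatter) and a 1.0-fold higher number from compound 2 to compound 4 (0.01 log units; within the scatter).

Going by these compounds, it remains open whether fluoro at this place gives the same result without the bromo group. On these data alone, how methoxy, an amine or a longer chain such as ethyl would read there also remains open.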